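A few compounds are considered here, and "the series" means these few. Any claim that something is new, unique, unknown or untested is made for them only; others in the source may bear on it.

Working notes on the series. Compound 1 `C#CCN(CCCCOc1ccc2ccc(=O)oc2c1)Cc1cccc(OC)c1` gives 2340 nM in an assay on isolated protein for inhibition of Amine oxidase [flavin-containing] B (Homo sapiens), read by fluorescence and Amplex Red, with stated times of 15 min and 20 min (a lower number here means a stronger inhibitor, a higher number a weaker inhibitor), the lowest of the three numbers recorded. Compound 2 `C#CCN(CCCOc1ccc2ccc(=O)oc2c1)Cc1ccc(OC)cc1` gives 6080 nM and compound 3 `C#CCN(CCCOc1ccc2ccc(=O)oc2c1)Cc1ccc(C)cc1` gives 7380 nM; both stand beyond the scatter from compound 1, and both differ from it in more than one place. Compound 4 `C#CCN(CCCCOc1ccc2ccc(=O)oc2c1)Cc1ccc(C)cc1` is not yet measured; it differs from compound 1 by 4-methylphenyl in place of 3-methoxyphenyl on a saturated chain carbon bound to an amine nitrogen. Among the measured compounds shown here, the only measured step that bears on this is a 1.2-fold higher number from compound 2 to compound 3 (0.08 log units; within the scatter), which covers the methyl-for-methoxy part but not the shift in the group's name from 3-methoxybenzyl to 4-methylbenzyl. The expected step is therefore small, a 1.3-fold higher number from compound 1 to compound 4 (0.11 log units; within the scatter), with a wide range for the unmeasured position change. Compound 4 is estimated at 3000 nM, between 1200 nM and 8000 nM.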

Compound 4, half-maximal inhibitory concentration: 1680 nM
The estimate for compound 4 lay 1.8-fold (0.25 log units) above the measured number; the range from low to high includes it.
By their numbers in this assay, from the lowest: compounds 4 and 1 (each within the scatter of the next); then compounds 2 and 3 (each within the scatter of the next).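

With the chain of compound 1 kept, 4-methylphenyl in place of 3-methoxyphenyl gives a 1.4-fold lower number from compound 1 to compound 4 (0.14 log units; within the scatter) in this assay. The earlier step covered only methyl for methoxy, whereas this one shows that a change of both group and ring position can also leave the number within the scatter. No measurement shown gives a reason for this result.

The effects of group and position remain unseparated, as 3-methylphenyl and 4-methoxyphenyl on the chain of compound 1 are not among the compounds shown. Also open, going by these compounds, is how a carboxylic acid or an amine on the phenyl ring would read.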